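A Chloro Substituent on the Anilide Ring of Compound 2

The source may hold more compounds than are shown below. What is called first, only, known or untested is meant among the compounds shown, and "the series" means these compounds.

Compound 1 `CCOC(=O)c1c(N)sc(C(=O)Nc2ccccc2)c1-c1ccccc1` gives 8580 nM in a functional assay on SMMC-7721 cells (Homo sapiens) for inhibition, read by MTT assay; a lower number here means a stronger inhibitor, a higher number a weaker inhibitor. Compound 2 `CCOC(=O)c1c(NC(=O)CC#N)sc(C(=O)Nc2ccccc2)c1-c1ccccc1` gives 530 nM. Compound 3 `N#CCC(=O)Nc1sc(C(=O)Nc2ccccc2)c(-c2ccccc2)c1C#N` gives 7930 nM.

Compound 2 has the lowest number of the three: the steps of a 16-fold lower number from compound 1 to compound 2 (1.21 log units; beyond the scatter) and a 15-fold higher number from compound 2 to compound 3 (1.17 log units; beyond the scatter) both set it apart, beyond the scatter. Compound 4 `CCOC(=O)c1c(NC(=O)CC#N)sc(C(=O)Nc2ccc(Cl)cc2)c1-c1ccccc1` differs from compound 2 by one change, (chloro in place of hydrogen on an aromatic carbon), turning the phenylcarbamoyl group into a (4-chlorophenyl)carbamoyl group. Neither measured step touches that ring; one concerns the amide nitrogen, the other the ethoxycarbonyl group, so nothing measured here shows how this chloro shifts the number. The expected step is therefore a 1.1-fold lower number from compound 2 to compound 4 (0.03 log units; within the scatter), no larger than the scatter. Compound 4 is estimated at 500 nM, within a range from 150 nM to 1600 nM.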

Compound 4, half-maximal inhibitory concentration: 730 nM
For compound 4 the middle estimate is 1.5-fold (0.16 log units) below the measured one; low and high end bracket the measured number.
By their numbers in this assay, from the lowest: compounds 2 and 4 (each within the scatter of the next); then compounds 3 and 1 (each within the scatter of the next).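

The earlier compounds shown here gave no measured step on the phenyl ring of the phenylcarbamoyl group, and here a 1.4-fold higher number from compound 2 to compound 4 (0.14 log units; within the scatter) stands in this assay as the first one. Chloro in place of hydrogen at this place therefore keeps compound 4 within the scatter of compound 2, unlike the large steps seen at the amide nitrogen and the ethoxycarbonyl group. No evidence here explains this result. Still open, going by these compounds, is whether a methoxy group, an amine or a carboxylic acid at this place would leave the number just as little changed.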